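Compound 3: ethoxy to propoxy on the chain

The source may hold more compounds than are shown below. What is called first, only, known or untested is meant among the compounds shown, and "the series" means these compounds.

Within the data shown here, in an ADME assay on a cell-free system (plasma, Homo sapiens) for metabolic stability, read by LC-MS (a lower number here means that the compound disappears faster, a higher number that the compound lasts longer), compound 2 `CCOC(=O)c1cccc(-c2cc(C(=O)Nc3ccncc3)ccc2CN)c1` gives 0.683 h, the lowest of the two numbers so far. Compound 1 `NCc1ccc(C(=O)Nc2ccncc2)cc1-c1cccc(C(=O)OCC2CCCCC2)c1` gives 1.65 h. Among the measured compounds shown here, the only measured step is a 2.4-fold lower number from compound 1 to compound 2 (0.38 log units; beyond the scatter), with methyl in place of cyclohexyl on a saturated chain carbon bound to an oxygen next to a carbonyl group.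

Compound 3 `CCCOC(=O)c1cccc(-c2cc(C(=O)Nc3ccncc3)ccc2CN)c1` has not yet been measured. It differs from compound 2 by methyl in place of hydrogen on a saturated chain carbon, two bonds along the chain from an oxygen next to a carbonyl group, which reads as ethoxy to propoxy.

For the measured compounds named here, the one measured step bears on this change. It alters the same chain, but at a different carbon and with a much larger group. It therefore suggests a direction more than a size, and two compounds establish no trend. The expectation of a higher number rests on compound 1, which has the larger group and gives 1.65 h. The expected step is a 1.2-fold higher number from compound 2 to compound 3 (0.09 log units; within the scatter), smaller than the measured one and possibly within the scatter. For compound 3 the estimated half-life is 0.85 h, with an expected range from 0.5 h to 1.45 h.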

Compound 3, half-life: 0.3 h
For compound 3 the middle estimate is 2.8-fold (0.45 log units) above the measured one; the measured number lies below the stated range.
By their numbers in this assay, from the lowest: compound 3; then compound 2; then compound 1.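

In this assay, ethoxy to propoxy gives a 2.3-fold lower number from compound 2 to compound 3 (0.36 log units; beyond the scatter), so adding one methyl at this chain carbon moves the half-life down and beyond the scatter. The larger alkoxy group therefore does not give the longer half-life across this set: the comparison of compound 1 with compound 2 alone left that reading open, and compound 3 goes against it, while cyclohexyl on the chain still stands well apart, with a 5.5-fold lower number from compound 1 to compound 3 (0.74 log units; beyond the scatter). No measurement on these compounds accounts for the fall in half-life or for the higher number carried by cyclohexyl.

From the compounds shown here alone, with three compounds, the series gives only a small and uneven picture of this chain, and it remains open whether butoxy would continue the fall seen with propoxy or reverse it, and whether methoxy would stand above or below ethoxy. Going by these compounds, it is also open how a branched isopropoxy group, or a phenyl ring in the place of cyclohexyl, would read against the straight chains and against the number for compound 1.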